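The source may hold more compounds than are shown below. What is called first, only, known or untested is meant among the compounds shown, and "the series" means these compounds.

Measured so far:
compound 1 `CCN(CC)C(=O)CO/N=C(\c1ccc(SC)cc1)c1cccc2ccccc12`: 25000 nM
compound 2 `CCCCC(CC)CNCCCO/N=C(\c1ccc(OC)cc1)c1cccc2ccccc12`: > 50000 nM

Among the compounds with values here, in a functional assay on HeLa cells (Homo sapiens) for antiproliferative activity, read by MTT assay, with a stated time of 24 h (a lower number here means that less compound is needed, a higher number that more compound is needed for the effect), compound 1 gives 25000 nM, the only actual number so far. Compound 2 reads > 50000 nM, which is a limit of the assay and not a number. Within the data shown here, no step between two measured compounds is available, so compound 1 has no second figure to be ranked against.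

Next in line is compound 3 `CSc1ccc(/C(=N\OCCCCN2CCCC2)c2cccc3ccccc23)cc1`. Its difference from compound 1 is 3-(pyrrolidin-1-yl)propyl in place of diethylcarbamoyl on a saturated chain carbon bound to an oxygen on an unsaturated carbon: 3-(pyrrolidin-1-yl)propyl takes the place of diethylcarbamoyl, on a saturated chain carbon bound to an oxygen on an unsaturated carbon.

With compound 1 at 25000 nM as the only anchor, no step beyond the usual scatter is expected in this assay, with a slight lean toward lower concentrations. The expected move is a 1.4-fold lower number from compound 1 to compound 3 (0.14 log units; within the scatter). For compound 3 the estimated value is 18000 nM, with an expected range of 5000 nM to 50000 nM.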

Compound 3, half-maximal effective concentration: > 50000 nM
Compound 3: only a limit was reported (the forecaster's own chance of this, stated with the estimate: 25%); at least 2.7-fold (0.44 log units) between middle value and limit.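

In this assay compound 3 gives > 50000 nM, which is a limit of the assay and not a number. Within the data shown here, on a saturated chain carbon bound to an oxygen on an unsaturated carbon, 3-(pyrrolidin-1-yl)propyl in place of diethylcarbamoyl gives the first step at this position, an at least 2.0-fold higher number from compound 1 to compound 3 (0.30 log units; that floor lies within the scatter), with no sign of a lower number from this replacement. The step remains a floor, without an upper end, because of where the reading sits: the limit of > 50000 nM in this assay, at which 2 of the 3 values shown sit.

Compound 1 remains the only actual number in the series, so the compounds shown do not tell how far this position can move in either direction. Open, on these data alone, is what a carboxylic acid, a morpholine or a primary amine at the end of the chain would give on the same core.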